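A few compounds are considered here, and "the series" means these few. Any claim that something is new, unique, unknown or untested is made for them only; others in the source may bear on it.

Of the compounds shown here, three have so far been measured in a physicochemical assay for lipophilicity, read by HPLC, measured as chromatographic lipophilicity, at pH 7.4; a lower number here means a more polar compound, a higher number a more lipophilic compound. Compound 1 `CC(C)(C)C(=O)N1CCNCC1c1ccccc1` gives 2.5. Compound 2 `CN1CCC(C(=O)N2N=CCC2c2ccccc2)CC1` gives 1.1, the lowest of the three numbers; compound 1 reads higher by a margin beyond the usual scatter. Compound 3 `N#Cc1cnc(N2CCC(C(=O)N3N=CC[C@H]3c3cc(F)cc(F)c3)CC2)cn1` gives 5.2, the highest of the three and far above compound 2, again well beyond the scatter.

Compound 4 `O=C(c1cc[nH]n1)N1CCC(C(=O)N2N=CCC2c2ccccc2)CC1` has not yet been measured in this assay. It differs from compound 2 in a single place: (1H-pyrazol-3-yl)carbonyl in place of methyl on an amine nitrogen in a ring. Within the data shown here, no two measured compounds differ in only one place, so no measured step shows directly what this change does; the expectation rests on the spread of the three known values. Compound 4 is expected to move upward from compound 2 by a step beyond the scatter, because compound 3, which also carries no methyl on the amine nitrogen in a ring, gives 5.2, while compound 4 is expected to stay well below compound 3. Compound 4 is therefore estimated at 2.8, with a likely range from 2 to 3.6. That estimate means an expected step of a number 1.70 log units higher from compound 2 to compound 4 (beyond the scatter).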

Compound 4, distribution coefficient: 2.4
The estimate for compound 4 lay 0.40 log units above the measured number; the range from low to high includes it.
By their numbers in this assay, from the lowest: compound 2; then compounds 4 and 1 (each within the scatter of the next); then compound 3.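

Placing (1H-pyrazol-3-yl)carbonyl in place of methyl on an amine nitrogen in a ring gives the first step in this assay that can be read for a single change: a number 1.30 log units higher from compound 2 to compound 4 (beyond the scatter) and this step counts as large. It shows that the group on this nitrogen can move the read-out substantially, at least in this one pair of compounds. No measurement shown here explains why the number rises.

The compounds shown leave open how much of the step belongs to the carbonyl and how much to the pyrazole ring, a split that an acetyl or benzoyl group on the same nitrogen would help to resolve. As far as these compounds go, it also remains open whether the same change would give a similar step on a different core.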